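The source may report more compounds than this note shows. Statements on the series, on what has been measured and on what is new or still open speak of the compounds shown alone.

Of the compounds shown here, three have been tested in a functional assay on HeLa cells (Homo sapiens) for antiproliferative activity, read by cell counting, with a stated time of 72 h; a lower number here means a stronger inhibitor, a higher number a weaker inhibitor. Compound 1 `C#C[C@@]1(O)[C@@H](CO)O[C@@H](n2cnc3c(-c4ccc(Cl)cc4)ncnc32)[C@@H]1O` gives 170000 nM. Compound 2 `C#C[C@@]1(O)[C@@H](CO)O[C@@H](n2cc(I)c3c(N)ncnc32)[C@@H]1O` gives 180 nM, the lower of the two actual numbers, and its gap to compound 1 lies beyond the usual scatter. Compound 3 `C#C[C@@]1(O)[C@@H](CO)O[C@@H](n2c(C(F)(F)F)cc3c(N)ncnc32)[C@@H]1O` reads > 250000 nM, which is a limit of the assay and not a number.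

Compound 4 `C#Cc1cn([C@@H]2O[C@H](CO)[C@](O)(C#C)[C@H]2O)c2ncnc(N)c12` has yet to be measured in this assay. It differs from compound 2 at one place, with ethynyl in place of iodo on an aromatic carbon. That carbon belongs to a five-membered aromatic ring with 1 nitrogen, part of a fused or bridged system of two rings, two ring bonds from the ring nitrogen.

For the measured compounds named here, no measured pair differs at only one place, so the size of this step cannot be read directly from the data. A modest move towards a higher number in this assay is expected, although a change within the scatter would be no surprise. Going by the values given here, this expectation rests on compound 2 already standing at 180 nM, the lowest number so far. The estimated change is a 2.2-fold higher number from compound 2 to compound 4 (0.35 log units; beyond the scatter). For compound 4 the expected value is 400 nM, with an estimated range from 80 nM to 3000 nM.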

Compound 4, half-maximal inhibitory concentration: 114000 nM
Estimate against measurement, compound 4: 290-fold (2.45 log units) below, outside the stated range (above it).
By their numbers in this assay, from the lowest: compound 2; then compounds 4 and 1 (each within the scatter of the next). At a limit, above all of these: compound 3.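

In this assay, for the compounds shown here, ethynyl in place of iodo gives a 630-fold higher number from compound 2 to compound 4 (2.80 log units; beyond the scatter), the first step at this aromatic carbon that can be read. The exchange is slight in what can be counted, with two heavy atoms entering for one and no hydrogen-bond donors or acceptors on either group, yet the step is large and beyond the scatter, so this position does not treat these two small groups alike. Compound 4 still gives an actual number, and only compound 3 rests at a limit of the assay rather than a number: the limit of > 250000 nM in this assay, at which 1 of the 4 values shown sits.

On these data alone, whether bromo or a methyl group on this carbon would stay close to compound 2 or fall as far as compound 4 remains open, and so does whether the large step belongs to ethynyl itself or to the loss of iodo. Compounds 1 and 3 differ from the others in more than one place, so their steps cannot be read, and these data do not tell what lies behind the large step.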